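This account rests on a few compounds, and the source may have more. Where it says the series, first, only, none or still open, it means among the compounds named here.

Measured in an ADME assay (liver, Mus musculus) for metabolic stability, read by LC-MS, using microsomes, tested at 1 uM; on this read-out lower numbers stand for a shorter-lived compound and higher numbers for a longer-lived compound:
- Compound 1 `CCN(CC)CCCCCN/C(C)=N\c1ccnc2cc(Cl)ccc12`: > 1 h
- Compound 2 `C/C(=N/c1ccnc2cc(Cl)ccc12)NCCCN1CCCCC1`: 0.417 h

The entry for compound 1, > 1 h, is a limit of the assay and not a number. Within the data shown here, compound 2, at 0.417 h, therefore holds the only true number so far, and it cannot yet be placed within a wider range of values.

The next compound is compound 3 `CCN(CC)CCN/C(C)=N\c1ccnc2cc(Cl)ccc12`. Its structural change is diethylamino in place of (piperidin-1-yl)methyl on a saturated chain carbon, two bonds along the chain from an amine nitrogen.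

Among the measured compounds shown here, only one measured step bears on this: an at least 2.3-fold lower number from compound 1 to compound 2 (0.37 log units; beyond the scatter). Going by these compounds, that step lies beyond the scatter, but it starts from a limit, so its full size is unknown. Compound 1 also carries a diethylamino group, though on a different chain, which makes it only a loose guide. A small rise in this assay is expected, not one clearly beyond the scatter, and the estimated step is a 1.4-fold higher number from compound 2 to compound 3 (0.16 log units; within the scatter). Compound 3 is expected to give 0.6 h, within an estimated range of 0.3 h to 1.3 h.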

Compound 3, half-life: 0.3 h
Beside the measured number, compound 3's estimate is 2.0-fold (0.30 log units) above it; the range from low to high includes it.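

Diethylamino in place of (piperidin-1-yl)methyl, on a saturated chain carbon, two bonds along the chain from an amine nitrogen, gives a 1.4-fold lower number from compound 2 to compound 3 (0.14 log units; within the scatter) in this assay, so this change separates compound 2 and compound 3 by no more than repeat measurements would. Compound 3 also shows that a diethylamino end does not by itself go with the reading of compound 1, since diethylamino in place of 3-(diethylamino)propyl at this place gives an at least 3.3-fold lower number from compound 1 to compound 3 (0.52 log units; beyond the scatter). The entry for compound 1 is a limit of the assay and not a number, so the full size of that step stays unknown, because it starts from a limit: the limit of > 1 h in this assay, at which 1 of the 3 values shown sits.

The compounds shown leave open how a diethylamino end would read on a chain of intermediate length, and so where along the chain the drop from compound 1 sets in. They also leave open whether another ring at the chain end, such as a pyrrolidine or a morpholine, would read like the piperidine of compound 2.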